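The source may report more compounds than this note shows. Statements on the series, on what has been measured and on what is new or still open speak of the compounds shown alone.

Working notes on the benzyloxy series, a functional assay on Vas deferens for antagonist activity at Alpha-1A adrenergic receptor (Rattus norvegicus); on this read-out lower numbers stand for lower potency and higher numbers for higher potency (the scale is a negative logarithm).

Compound 1 `COc1cccc(OC)c1OCCNCCOc1ccccc1OCc1ccccc1` carries an unsubstituted benzyl group and gives 8.39 in this assay. Compound 2 `COc1cccc(OC)c1OCCNCCOc1ccccc1OCc1ccc(C)cc1` replaces that group with a 4-methylbenzyl and gives 8.23; the step of a number 0.16 log units lower from compound 1 to compound 2 (within the scatter) stays within the scatter. Compound 3 `COc1ccccc1COc1ccccc1OCCNCCOc1c(OC)cccc1OC` carries a 2-methoxybenzyl and gives 8.53. Compound 3 holds the highest number of the three, but neither the step of a number 0.14 log units higher from compound 1 to compound 3 (within the scatter) nor the step of a number 0.30 log units higher from compound 2 to compound 3 (within the scatter) goes beyond the scatter, so no order among the three is established.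

Compound 4 `COc1ccc(COc2ccccc2OCCNCCOc2c(OC)cccc2OC)cc1` has the same atoms as compound 3, joined differently: 4-methoxyphenyl in place of 2-methoxyphenyl on a saturated chain carbon bound to an oxygen on an aromatic ring. For the measured compounds named here, two measured steps bear on it. The change from compound 1 to compound 2 puts a methyl at the 4-position of the benzyl and moves the number by a number 0.16 log units lower from compound 1 to compound 2 (within the scatter); the change from compound 2 to compound 3 swaps 4-methylphenyl for 2-methoxyphenyl and moves it by a number 0.30 log units higher from compound 2 to compound 3 (within the scatter). Both lie within the scatter, so in this assay the step to compound 4 is expected to be small, if anything slightly downward, as a number 0.23 log units lower from compound 3 to compound 4 (within the scatter). Compound 4 is therefore estimated at 8.3, with a range from 7.8 to 8.7.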

Compound 4, negative logarithm of the antagonist equilibrium constant: 8.54
Estimate against measurement, compound 4: 0.24 log units below; measured number inside the range.
By their numbers in this assay, from the lowest: compounds 2, 1, 3 and 4 (each within the scatter of the next, the first and the last beyond it).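

In this assay, moving the methoxy from 2-methoxybenzyl to 4-methoxybenzyl on the saturated chain carbon bound to an oxygen on an aromatic ring gives a number 0.01 log units higher from compound 3 to compound 4 (within the scatter), so the series so far shows no dependence on where this methoxy stands among these two placements. For the compounds shown here, the same compound supplies the first step that clears the scatter: methoxy in place of methyl on an aromatic carbon gives a number 0.31 log units higher from compound 2 to compound 4 (beyond the scatter), a modest separation that the earlier compounds did not provide, while a number 0.15 log units higher from compound 1 to compound 4 (within the scatter) leaves the unsubstituted benzyl of compound 1 unseparated from compound 4, and compound 2 is likewise within the scatter of compound 1. No measurement is available here that would account for any of these steps.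

The compounds shown leave open whether the separation between methoxy and methyl at this place extends to other groups, such as a 4-ethoxybenzyl, a 4-hydroxybenzyl or a 4-chlorobenzyl. They also leave open what a longer chain, such as a 2-phenylethyl in place of the benzyl, would do in this assay.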